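Oleamide anilides: from difluoro anilide to dialkyl anilide

The compounds below may be only part of what the source reports. "The series", "measured", "known", "first", "only" and "open" are said of these compounds alone.

Two oleamide anilides have been measured in an assay on microsomes from intestine for inhibition of acyl-CoA:cholesterol acyltransferase (Oryctolagus cuniculus); on this read-out higher numbers stand for weaker inhibition and lower numbers for stronger inhibition. Compound 1 `CCCCCCCC/C=C/CCCCCCCC(=O)Nc1ccccc1C(=O)c1ccccc1` gives > 10000 nM, which is a limit of the assay and not a number. Going by the values given here, compound 2 `CCCCCCCC/C=C/CCCCCCCC(=O)Nc1ccc(F)cc1F` gives 32000 nM in this assay, the only number in the set, and it stands at weak inhibition. Compound 1 sits at the limit of > 10000 nM in this assay, at which 1 of the 2 values shown sits, so no order between compound 1 and compound 2 can be drawn. Compound 3 `CCCCCCCC/C=C/CCCCCCCC(=O)Nc1c(C)cccc1C(C)C` has not been measured. It differs from compound 2 in one place: a group of 10 heavy atoms (10 carbon; one six-membered aromatic ring of carbon only) in place of a group of 8 heavy atoms (6 carbon, 2 fluorine; one six-membered aromatic ring of carbon only), on an amide-type nitrogen. Among the compounds with values here, no step between two measured compounds exists in the set, so the expected size of the step rests on the change alone. The expected step is a 16-fold lower number from compound 2 to compound 3 (1.20 log units; beyond the scatter) in this assay, toward stronger inhibition and beyond the scatter. Compound 3 is estimated at 2000 nM, with a range from 300 nM to 10000 nM.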

Compound 3, half-maximal inhibitory concentration: 23 nM
Beside the measured number, compound 3's estimate is 87-fold (1.94 log units) above it; the measured number lies below the stated range.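

The group on the amide-type nitrogen sets the level of inhibition in this assay: replacing 2,4-difluorophenyl with the carbon-only aryl group gives a 1400-fold lower number from compound 2 to compound 3 (3.14 log units; beyond the scatter), toward stronger inhibition. Both groups hold one six-membered aromatic ring of carbon only, with no hydrogen-bond donors, no hydrogen-bond acceptors and no net charge, so the presence of that ring does not by itself give compound 3 its level. No measurement in the set gives a reason for a step of this size.

From the compounds shown here alone, the whole group changes in this one step, so it stays open which part of it carries the gain. Going by these compounds, it is also open whether a chlorine or methoxy group on the ring, or a shorter chain on the carbonyl, would keep inhibition at the level of compound 3.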